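A few compounds are considered here, and "the series" means these few. Any claim that something is new, unique, unknown or untested is made for them only; others in the source may bear on it.

In a toxicity assay on THP-1 cells (Homo sapiens) for inhibition (a higher number here means that more compound is tolerated, a lower number that less compound is tolerated), the three measured compounds stand as follows:

Compound 1, `COc1ccccc1-c1cnc(NC(=O)c2ccc(F)cc2)n1C`, gives a limit of > 100000 nM.
Compound 2, `Cn1c(-c2cccc([N+](=O)[O-])c2)cnc1NC(=O)c1ccc(F)cc1`, gives a limit of > 50000 nM.
Compound 3, `Cn1c(-c2cccc(F)c2)cnc1NC(=O)c1ccc(F)cc1`, gives 58000 nM.

Compound 3 is thus the only one of the three with a number; the other two values are limits rather than numbers. Compound 4, `Cn1c(-c2ccc(F)cc2)cnc1NC(=O)c1ccc(F)cc1`, differs from compound 3 only in one place: 4-fluorophenyl in place of 3-fluorophenyl on an aromatic carbon.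

Two measured steps lead into compound 3. The step of an at least 1.7-fold lower number from compound 1 to compound 3 (0.23 log units; that floor lies within the scatter) sits on a floor that lies within the usual scatter. The step that the limit leaves unreadable from compound 2 to compound 3 cannot be sized. Neither step moves a fluorine from one place on the same ring to another, so nothing here points to a change beyond the scatter, in either direction.

For compound 4 the expectation in this assay is therefore 58000 nM, with a range from 25000 nM to 140000 nM. That estimate amounts to no change at the digits printed from compound 3 to compound 4 (within the scatter).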

Compound 4, half-maximal cytotoxic concentration: > 100000 nM
Compound 4: no number, only a limit (the forecaster's own chance of this, stated with the estimate: 40%); middle value at least 1.7-fold (0.23 log units) from the limit.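

In this assay, within the data shown here, moving the fluorine from 3-fluorophenyl to 4-fluorophenyl is the first change here that keeps the same atoms and only joins them differently, and it gives an at least 1.7-fold higher number from compound 3 to compound 4 (0.23 log units; that floor lies within the scatter). Compound 4 gives > 100000 nM, which is a limit of the assay and not a number, so this step has only a floor, and that floor does not show a change beyond the scatter. Compound 4 thus sits at the same limit as compound 1: the limit of > 100000 nM in this assay, at which 2 of the 4 values shown sit.

The step between compound 1 and compound 4 joins two limits and cannot be read. Still open, on these data alone, is how 2-fluorophenyl would read in this assay, and whether an amine or a carboxylic acid in the place of the fluorine would bring a number well under these limits.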